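The source may report more compounds than this note shows. Statements on the series, on what has been measured and on what is new or still open speak of the compounds shown alone.

Measured in a functional assay on A549 cells (Homo sapiens) for cytotoxicity, read by MTT assay; on this read-out higher numbers stand for weaker inhibition and lower numbers for stronger inhibition:
- compound 1 `C=C1C(=O)[C@]23C[C@@]1(Cl)CC[C@H]2[C@@]12C=CC(=O)[C@](C)(C(=O)O1)[C@H]2[C@@H]3C(=O)OCc1ccccc1`: 28800 nM
- compound 2 `C=C1C(=O)[C@]23C[C@@]1(F)CC[C@H]2[C@@]12C=CC(=O)[C@](C)(C(=O)O1)[C@H]2[C@@H]3C(=O)OC`: 38900 nM

Going by the values given here, only these two compounds have numbers so far. The value of compound 2 lies within the usual scatter of the value of compound 1, so the two cannot be ranked against each other.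

The next compound, compound 3 `C=C1C(=O)[C@]23C[C@@]1(F)CC[C@H]2[C@@]12C=CC(=O)[C@](C)(C(=O)O1)[C@H]2[C@@H]3C(=O)OCc1ccccc1`, follows from compound 2 by one change: phenyl in place of hydrogen on a saturated chain carbon bound to an oxygen next to a carbonyl group. In words, this is phenyl in place of hydrogen on a saturated chain carbon bound to an oxygen next to a carbonyl group, so that methoxycarbonyl becomes benzyloxycarbonyl.

Among the compounds with values here, no measured pair shows this change on its own, so its size in this assay cannot be read directly. With compound 1 at 28800 nM and compound 2 at 38900 nM, the measured numbers give no hint of a large shift, and no step beyond the scatter is expected. The estimated change is a 1.3-fold lower number from compound 2 to compound 3 (0.10 log units; within the scatter). The estimate for compound 3 is 31000 nM, with an expected range from 13000 nM to 70000 nM.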

Compound 3, half-maximal inhibitory concentration: 64400 nM
Compound 3: middle estimate off by 2.1-fold (0.32 log units), on the low side; measured number inside the range.
By their numbers in this assay, from the lowest: compounds 1, 2 and 3 (each within the scatter of the next, the first and the last beyond it).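

In this assay, extending methoxycarbonyl to benzyloxycarbonyl on the fluoro compounds gives a 1.7-fold higher number from compound 2 to compound 3 (0.22 log units; within the scatter) and so cannot be told apart from repeat scatter: phenyl in place of hydrogen on this saturated chain carbon bound to an oxygen next to a carbonyl group shows no clear step in this single pair. Going by these compounds alone, with benzyloxycarbonyl held constant, the change on the saturated ring carbon can now be read on its own, and fluoro in place of chloro gives a 2.2-fold higher number from compound 1 to compound 3 (0.35 log units; beyond the scatter) as the only step here beyond the scatter, a modest one resting on one pair. Nothing available explains either step.

The compounds shown leave open whether the fluoro-for-chloro step would hold with methoxycarbonyl in place of benzyloxycarbonyl, and how a bromo group on the same ring carbon would compare. They also leave open how a free carboxylic acid, an amide or a longer chain such as phenylethyl would read at the position of the ester oxygen's substituent.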